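Enantiomer swap on the bisphosphate carrier chain

This account rests on a few compounds, and the source may have more. Where it says the series, first, only, none or still open, it means among the compounds named here.

Going by the values given here, compound 2 `CNc1nc(Cl)nc2c1ncn2C[C@H](COP(=O)(O)O)OP(=O)(O)O` gives 7860 nM in an assay on cell membranes for inhibition of P2Y purinoceptor 1 (Meleagris gallopavo) (a lower number here means a stronger inhibitor, a higher number a weaker inhibitor), and holds the higher of the two numbers measured so far; compound 1 `CNc1nc(Cl)nc2c1ncn2CC(COP(=O)(O)O)COP(=O)(O)O` gives 480 nM in this assay, a lower number beyond the scatter. Compound 3 `CNc1nc(Cl)nc2c1ncn2C[C@@H](COP(=O)(O)O)OP(=O)(O)O` is the mirror form of compound 2: the two compounds have the same atoms and bonds and differ only in configuration as drawn: 1 of 1 stereo elements differ; a stereocentre at a saturated chain carbon is drawn R in compound 2 and S in compound 3. Among the compounds with values here, no pair of measured compounds differs by configuration alone, so the direction of this step is not anchored by data. A move toward a lower number, beyond the scatter, is expected for compound 3, with compound 2 sitting at the weak end of what has been seen. The expected step is a 3.9-fold lower number from compound 2 to compound 3 (0.59 log units; beyond the scatter). Compound 3 is estimated at 2000 nM, within 400 nM to 10000 nM.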

Compound 3, half-maximal inhibitory concentration: 1470 nM
Estimate against measurement, compound 3: 1.4-fold (0.13 log units) above; low and high end bracket the measured number.
By their numbers in this assay, from the lowest: compound 1; then compound 3; then compound 2.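

In this assay the configuration at this saturated chain carbon carries a real difference, with the form drawn S as the stronger inhibitor: the step is a 5.3-fold lower number from compound 2 to compound 3 (0.73 log units; beyond the scatter) and counts as modest. This pair gives the series its first direction for a change of configuration, and that step can be put down to configuration alone because of one fact: (the fact that compounds 2 and 3 differ only in the configuration as drawn).

Still open, on these data alone, is whether the preference for the S form holds with a carboxylic acid or a phosphonate in place of either phosphate. A longer chain between the core and the phosphates is equally untested here.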